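A few compounds are considered here, and "the series" means these few. Any claim that something is new, unique, unknown or untested is made for them only; others in the source may bear on it.

In a functional assay on KB 3-1 cells (Homo sapiens) for cytotoxicity, read by MTT assay, with a stated time of 68 h (on this read-out higher numbers stand for weaker inhibition and lower numbers for stronger inhibition), three compounds have been measured:

- Compound 1 `COc1ccc(-c2cc(NC(=O)C(Cl)Cl)cc(-c3ccc(OC)cc3)c2)cc1`: > 30000 nM (a limit)
- Compound 2 `O=C(Nc1cccc(-c2ccccc2C(F)(F)F)c1)C(Cl)Cl`: 35900 nM
- Compound 3 `O=C(Nc1cccc(-c2ccsc2)c1)C(Cl)Cl`: > 50000 nM (a limit)

Compound 1 has no exact number, only (the limit of > 30000 nM in this assay, at which 1 of the 3 values shown sits). Compound 3 likewise has only (the limit of > 50000 nM in this assay, at which 1 of the 3 values shown sits). Compound 2 is therefore the only one of the three with an exact number, and these data give no firm order among them.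

The next compound to be tested is compound 4 `COc1ccc(-c2cccc(NC(=O)C(Cl)Cl)c2)cc1`, which keeps the ((dichloromethyl)carbonyl)amino group of compound 1. The change is hydrogen in place of 4-methoxyphenyl on an aromatic carbon.

In this assay, no step beyond the usual scatter is expected, and no direction is favoured. Like compound 4, compound 2 carries a single aromatic ring as its other substituent, and it gives 35900 nM. Compound 3 is also of this kind, and its result is a limit, so compound 4 may likewise return only a limit. The expected change is a step that the limit leaves unreadable from compound 1 to compound 4. For compound 4 the estimated value is 40000 nM, with an expected range from 15000 nM to 100000 nM.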

Compound 4, half-maximal inhibitory concentration: > 50000 nM
Compound 4 ended at the assay's limit; the forecaster's own chance of this, stated with the estimate: 55%; middle value at least 1.2-fold (0.09 log units) from the limit.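

In this assay compound 1 and compound 4 each stand only as a limit, so no step can be read for hydrogen in place of 4-methoxyphenyl on an aromatic carbon. The compounds shown leave open whether this change shifts the read-out at all, and what exact number compound 4 would take.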